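Swapping Fluoro for Chloro on Compound 1

A few compounds are considered here, and "the series" means these few. Any claim that something is new, unique, unknown or untested is made for them only; others in the source may bear on it.

In an ADME assay on MT4 cells (Homo sapiens) for cytotoxicity, read by spectrophotometry, with a stated time of 5 days (on this read-out lower numbers stand for higher toxicity in this test and higher numbers for lower toxicity in this test), compound 1 `CONC(=S)N/N=C1\C(=O)N(CN2CCN(c3c(F)cc4c(=O)c(C(=O)O)cn(C5CC5)c4c3OC)CC2C)c2ccc(F)cc21` gives 171000 nM, the lowest of three numbers. Compound 3 `CONC(=S)N/N=C1\C(=O)N(CN2CCN(c3ccccc3)CC2)c2ccc(C)cc21` gives 276000 nM, which lies within the scatter of compound 1. Compound 2 `CONC(=S)N/N=C1\C(=O)N(CN2CCN(c3ccc(Cl)cc3)CC2)c2ccc(F)cc21` gives 347000 nM, a higher number than compound 1 and beyond the scatter. Compound 4 `CONC(=S)N/N=C1\C(=O)N(CN2CCN(c3c(F)cc4c(=O)c(C(=O)O)cn(C5CC5)c4c3OC)CC2C)c2ccc(Cl)cc21` differs from compound 1 by chloro in place of fluoro on an aromatic carbon of the shared core (chloro in place of fluoro on an aromatic carbon). Among the measured compounds shown here, no measured pair differs at a single place, so the data offer no direct guide to this swap in this assay. The expected change is small and stays within the scatter, with no firm direction, a 1.0-fold lower number from compound 1 to compound 4 (0.02 log units; within the scatter). Compound 4 is estimated at 165000 nM, with an expected range of 90000 nM to 300000 nM.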

Compound 4, half-maximal cytotoxic concentration: 164000 nM
Compound 4: middle estimate off by 1.0-fold (0.00 log units), on the high side, within the range that was stated.
By their numbers in this assay, from the lowest: compounds 4, 1, 3 and 2 (each within the scatter of the next, the first and the last beyond it).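

In this assay, the first pair differing at a single place shows that chloro in place of fluoro on an aromatic carbon of the shared core gives a step within the scatter (a 1.0-fold lower number from compound 1 to compound 4 (0.02 log units; within the scatter)). At this position, meta to a fused ring and para to a fused ring, the two halogens cannot be told apart on this read-out. Nothing measured here explains this result. As far as these compounds go, whether a nitrile or an amine at this position would give a number beyond the scatter remains open.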